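The source may report more compounds than this note shows. Statements on the series, on what has been measured and on what is new or still open speak of the compounds shown alone.

Compounds measured so far in a functional assay on Jurkat cells for inhibition of nuclear factor NF-kappa-B complex (Homo sapiens); on this read-out lower numbers stand for stronger inhibition and higher numbers for weaker inhibition:
- compound 1 `CCOC(=O)c1cnc(-c2cccs2)nc1NN1C(=O)C=C(C)C1=O`: 20 nM
- compound 2 `CCOC(=O)c1cnc(-c2ccc(OC)cc2)nc1NN1C(=O)C=C(C)C1=O`: 900 nM
- compound 3 `CCOC(=O)c1cnc(-c2ccc(Cl)cc2)nc1NN1C(=O)C=C(C)C1=O`: 300 nM

Compound 3 stands second highest of the three numbers in this assay: its nearest neighbour is compound 2, with a 3.0-fold lower number from compound 2 to compound 3 (0.48 log units; beyond the scatter), and the furthest is compound 1, with a 15-fold higher number from compound 1 to compound 3 (1.18 log units; beyond the scatter). All three measured steps touch the same aromatic carbon of the shared core: a 45-fold higher number from compound 1 to compound 2 (1.65 log units; beyond the scatter) and a 15-fold higher number from compound 1 to compound 3 (1.18 log units; beyond the scatter) are large, a 3.0-fold lower number from compound 2 to compound 3 (0.48 log units; beyond the scatter) is modest. The position is therefore clearly sensitive to what is attached there.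

Compound 4 `CCOC(=O)c1cnc(S(=O)(=O)c2ccccc2)nc1NN1C(=O)C=C(C)C1=O` differs from compound 3 by phenylsulfonyl in place of 4-chlorophenyl on an aromatic carbon. Among the compounds with values here, no measured pair carries a phenylsulfonyl group, and no measured pair separates the phenyl ring from the core by a sulfonyl, so the three steps bear on compound 4 only in showing how much this position can move, not in which direction. Given that every change at this carbon away from thiophen-2-yl has so far raised the number, the step is expected to be a 5.0-fold higher number from compound 3 to compound 4 (0.70 log units; beyond the scatter), with wide uncertainty in both directions. Compound 4 is thus estimated at 1500 nM in this assay, within a range of 300 nM to 8000 nM.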

Compound 4, half-maximal inhibitory concentration: 10000 nM
Beside the measured number, compound 4's estimate is 6.7-fold (0.82 log units) below it, outside the stated range (above it).
By their numbers in this assay, from the lowest: compound 1; then compound 3; then compound 2; then compound 4.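

In this assay, phenylsulfonyl on this aromatic carbon gives the weakest inhibition of the four compounds, with a 33-fold higher number from compound 3 to compound 4 (1.52 log units; beyond the scatter), an 11-fold higher number from compound 2 to compound 4 (1.05 log units; beyond the scatter) and a 500-fold higher number from compound 1 to compound 4 (2.70 log units; beyond the scatter). The position therefore spans a wider range than the three groups with a ring attached directly to the core had shown, and thiophen-2-yl remains the group with the lowest number. Nothing at hand bears on why this change raises the number.

The step from 4-chlorophenyl to phenylsulfonyl adds a sulfonyl and removes the chloro in one move, so the compounds shown do not separate the contribution of either change. Still open, on these data alone, is how a plain phenyl, a phenylthio or a phenylamino group would read at this carbon, and whether another five-membered ring such as furan-2-yl or a small amine such as morpholine would stay near the number of compound 1 or move towards that of compound 4.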